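Cytotoxicity of a Phenoxy-to-Alkyl Swap on a Shared Core

The source may report more compounds than this note shows. Statements on the series, on what has been measured and on what is new or still open speak of the compounds shown alone.

The measured compounds and their values:
compound 1, `c1ccc(Oc2ccc3c(NCCCNCc4ccco4)ccnc3c2)cc1`, 15200 nM
compound 2, `COc1cccc(CNCCCNc2ccnc3cc(Oc4ccccc4)ccc23)c1O`, 6800 nM
compound 3, `COc1ccc(F)cc1CNCCCNc1ccnc2cc(Cc3ccc(C#N)cc3)ccc12`, 6050 nM

In an ADME assay on HepG2 cells (Homo sapiens) for cytotoxicity, read by luminescence, CellTiter-Glo and ATP content, with a stated time of 72 h (a higher number here means that more compound is needed for the effect, a lower number that less compound is needed), compound 1 gives the highest number of the three. Its nearest neighbour is compound 2, reached by a 2.2-fold lower number from compound 1 to compound 2 (0.35 log units; beyond the scatter), a change at the far end of the chain rather than on the aromatic ring. Compound 3 stands further off, with a lower number still, but it differs from compound 1 in more than one place, so only its value is known, not a step.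

Compound 4, `CCC(CC)c1ccc2c(NCCCNCc3ccco3)ccnc2c1`, differs from compound 1 as follows: pentan-3-yl in place of phenoxy on an aromatic carbon. Among the compounds with values here, no measured step touches this position: the one step available, from compound 1 to compound 2, alters the chain end and not the aromatic carbon, so it offers no direct guide. With nothing bearing on the change, the expectation for this assay is a step of no more than modest size in either direction, most likely none beyond the scatter, so that compound 4 is estimated at 14000 nM, within 5000 nM to 40000 nM. That expectation corresponds to a 1.1-fold lower number from compound 1 to compound 4 (0.04 log units; within the scatter).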

Compound 4, half-maximal effective concentration: 6760 nM
The estimate for compound 4 lay 2.1-fold (0.32 log units) above the measured number; the measured number falls inside the stated range.
By their numbers in this assay, from the lowest: compounds 3, 4 and 2 (each within the scatter of the next); then compound 1.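

In this assay the position on the aromatic carbon proves responsive, with a step of a 2.2-fold lower number from compound 1 to compound 4 (0.35 log units; beyond the scatter). Phenoxy can therefore give way to pentan-3-yl, losing the aromatic ring and the oxygen, without raising the number, and the move goes the same way as the change at the chain end, a 2.2-fold lower number from compound 1 to compound 2 (0.35 log units; beyond the scatter). No measurement shown here bears on what lies behind this result.

Since phenoxy and pentan-3-yl differ in both ring and oxygen, the compounds shown cannot tell which of the two matters; cyclohexyloxy, which keeps the oxygen without the aromatic ring, and a directly attached phenyl ring, which keeps the aromatic ring without the oxygen, would separate them. Also open, from the compounds shown here alone, is whether pentan-3-yl and the 2-hydroxy-3-methoxyphenyl chain end would combine their steps on the shared core.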